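Working notes on a small selenium series

The compounds below may be only part of what the source reports. "The series", "measured", "known", "first", "only" and "open" are said of these compounds alone.

Measured so far:
compound 1, `C[Se]c1nc(N)c2ccccc2n1`: 74800 nM
compound 2, `Nc1nc([SeH])nc2ccccc12`: > 100000 nM

Among the measured compounds shown here, in a functional assay on HT-29 cells (Homo sapiens) for cytotoxicity, read by MTT assay, with a stated time of 72 h (on this read-out higher numbers stand for weaker inhibition of growth and lower numbers for stronger inhibition of growth), compound 1 gives 74800 nM, the only numerical value in the set. Compound 2 reaches only a limit of the assay, > 100000 nM. For the measured compounds named here, the sole measured step, an at least 1.3-fold higher number from compound 1 to compound 2 (0.12 log units; that floor lies within the scatter), rests on (the limit of > 100000 nM in this assay, at which 1 of the 2 values shown sits). Compound 3, `C[Se]c1nc([Se]C)c2ccccc2n1`, differs from compound 1 by a group of 2 heavy atoms (1 carbon, 1 selenium; no ring) in place of one nitrogen atom, on an aromatic carbon. Going by the values given here, no measured step touches the amino group, so this change has no direct precedent, and the one measured step concerns the selenium substituent and cannot be carried over. For compound 3 the expected step is a 1.3-fold higher number from compound 1 to compound 3 (0.13 log units; within the scatter), likely within the scatter or ending at a limit. Compound 3 is estimated at 100000 nM, between 40000 nM and 250000 nM.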

Compound 3, concentration for total growth inhibition: 33800 nM
Beside the measured number, compound 3's estimate is 3.0-fold (0.47 log units) above it; the whole stated range lies above it.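

In this assay, the amino group on this aromatic carbon proves dispensable for the growth inhibition seen: a group of 2 heavy atoms (1 carbon, 1 selenium; no ring) in its place gives a 2.2-fold lower number from compound 1 to compound 3 (0.34 log units; beyond the scatter). Among the compounds shown here, this is the first step beyond the scatter, though a modest one, and it comes with the loss of the hydrogen-bond donor and acceptor counted on amino. Nothing shown here bears on why the number falls.

Going by these compounds, whether the selenium or the added carbon carries this step remains open. A methoxy or methylthio group on this aromatic carbon would separate the two.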